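Swapping cyclopropylamino for oxetan-3-yl on a sulfonyl sulfur

This account rests on a few compounds, and the source may have more. Where it says the series, first, only, none or still open, it means among the compounds named here.

Measured in an ADME assay on microsomes from liver (Homo sapiens) for metabolic stability, read by LC-MS, with a stated time of 40 min, tested at 0.5 uM; a higher number here means faster removal of the compound, a lower number slower removal:
Compound 1 `CC(C)(C)NS(=O)(=O)c1cccc(NC(=O)c2cccnc2N2CCC3(CC2)CC3)c1`: > 399 mL.min-1.g-1 (a limit)
Compound 2 `O=C(Nc1cccc(S(=O)(=O)NC2CC2)c1)c1cccnc1N1CCC2(CC1)CC2`: > 399 mL.min-1.g-1 (a limit)

Compound 2 gives > 399 mL.min-1.g-1, which is a limit and not a number. Compound 3 `O=C(Nc1cccc(S(=O)(=O)C2COC2)c1)c1cccnc1N1CCC2(CC1)CC2` differs from it as follows: oxetan-3-yl in place of cyclopropylamino on a sulfonyl sulfur. Within the data shown here, the one measured step is a step that the two limits leave unreadable from compound 1 to compound 2, and it gives no size to carry over. The shared core remains, and with the limit of > 399 mL.min-1.g-1 in this assay, at which 2 of the 2 values shown sit, only a modest fall, if any, is expected in this assay. The expected change is an at least 1.4-fold lower number from compound 2 to compound 3 (0.15 log units; that floor lies within the scatter). For compound 3 the estimate is 280 mL.min-1.g-1, with an expected range of 110 mL.min-1.g-1 to 650 mL.min-1.g-1.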

Compound 3, intrinsic clearance in microsomes: 183 mL.min-1.g-1
The estimate for compound 3 lay 1.5-fold (0.18 log units) above the measured number, and the stated range covers the measured number.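

In this assay, oxetan-3-yl on the sulfonyl sulfur gives an at least 2.1-fold lower number from compound 2 to compound 3 (0.33 log units; beyond the scatter), and the same group set against (tert-butyl)amino gives an at least 2.1-fold lower number from compound 1 to compound 3 (0.33 log units; beyond the scatter). Both sizes are floors. Compound 1 and compound 2 each sit at a limit, and the step between them cannot be read: the limit of > 399 mL.min-1.g-1 in this assay, at which 2 of the 3 values shown sit.

As far as these compounds go, the true size of either fall remains open, since it starts from a limit. Also open, from the compounds shown here alone, is whether the ring oxygen or the loss of the sulfonamide nitrogen matters, which a directly attached cyclopropyl or a morpholine on the sulfonyl sulfur could help separate.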